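Urea analogues against breast cancer cells: swapping two rings

The source may hold more compounds than are shown below. What is called first, only, known or untested is meant among the compounds shown, and "the series" means these compounds.

Measured so far:
compound 1 `O=C(Nc1ccc(Oc2ccc(-c3nccs3)cc2)cc1)Nc1ccc(F)c(C(F)(F)F)c1` — 71.8%
compound 2 `Cc1ccc(NC(=O)Nc2ccc(Oc3ccc(-c4nccs4)cc3)cc2)cc1` — 22.8%
compound 3 `O=C(Nc1ccc(Oc2ccc(-c3ncc[nH]3)cc2)cc1)Nc1ccc(F)c(C(F)(F)F)c1` — 26.6%

All three share one urea core and were tested in a functional assay on MDA-MB-231 cells (Homo sapiens) for inhibition, read by MTT assay and WST assay, with a stated time of 72 h, tested at 10 uM; on this read-out higher numbers stand for more inhibition of growth at the one concentration tested and lower numbers for less inhibition of growth. Two changes from compound 1 are known. The first, (4-methylphenyl in place of 4-fluoro-3-(trifluoromethyl)phenyl on an amide-type nitrogen), gave a number 49 percentage points lower from compound 1 to compound 2 (beyond the scatter). The second, (1H-imidazol-2-yl in place of 1,3-thiazol-2-yl on an aromatic carbon), gave a number 45.2 percentage points lower from compound 1 to compound 3 (beyond the scatter). Compound 4 `Cc1ccc(NC(=O)Nc2ccc(Oc3ccc(-c4ncc[nH]4)cc3)cc2)cc1` is not yet measured; it differs from compound 3 by 4-methylphenyl in place of 4-fluoro-3-(trifluoromethyl)phenyl on an amide-type nitrogen, which is the same change that separates compound 1 from compound 2, made at the same place. Compound 3 already stands low, so the step is expected to be smaller than the earlier one: a number 16.6 percentage points lower from compound 3 to compound 4 (beyond the scatter), resting on a number 49 percentage points lower from compound 1 to compound 2 (beyond the scatter) and on compound 3 giving 26.6%. Compound 4 is estimated at 10%, between 0% and 25%.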

Compound 4, percent growth inhibition at one concentration: 49.3%
The estimate for compound 4 lay 39.3 percentage points below the measured number, outside the stated range (above it).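

Putting 4-methylphenyl in place of 4-fluoro-3-(trifluoromethyl)phenyl gave a number 22.7 percentage points higher from compound 3 to compound 4 (beyond the scatter), so this change reverses direction once 1H-imidazol-2-yl replaces 1,3-thiazol-2-yl: the same change on two cores in this assay, a number 49 percentage points lower (beyond the scatter) from compound 1 to compound 2 and a number 22.7 percentage points higher (beyond the scatter) from compound 3 to compound 4, 71.7 percentage points apart, beyond the scatter of two such steps The ring swap reverses in the same way, with 1H-imidazol-2-yl in place of 1,3-thiazol-2-yl giving a number 26.5 percentage points higher from compound 2 to compound 4 (beyond the scatter): the same change on two cores in this assay, a number 45.2 percentage points lower (beyond the scatter) from compound 1 to compound 3 and a number 26.5 percentage points higher (beyond the scatter) from compound 2 to compound 4, 71.7 percentage points apart, beyond the scatter of two such steps The effect of each change therefore depends on the other in these four compounds, but this does not show why, nor how either change would behave on any further core.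

Still open, going by these compounds, is whether the reversal holds for other groups on the amide-type nitrogen, such as unsubstituted phenyl. The same question applies to an amine or a carboxylic acid in place of the ring on the aromatic carbon.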